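A few compounds are considered here, and "the series" means these few. Any claim that something is new, unique, unknown or untested is made for them only; others in the source may bear on it.

Measured compounds:
- compound 1 `CNc1cc(Oc2c(F)cc(NC(=O)Nc3cccc(C(F)(F)F)c3)cc2F)ncn1`: 20 nM in an assay on isolated protein for inhibition of serine/threonine-protein kinase TNNI3K (Homo sapiens); on this read-out higher numbers stand for weaker inhibition and lower numbers for stronger inhibition
- compound 2 `COc1cc(Oc2ccc(NC(=O)Nc3cccc(C(F)(F)F)c3)cc2)ncn1`: in this assay compound 2 gives 4000 nM
- compound 3 `CNc1cc(Oc2cc(C)c(NC(=O)Nc3cccc(C(F)(F)F)c3)cc2C)ncn1`: in this assay compound 3 gives 32 nM

Compound 2 carries the highest number of the three in this assay. Its gap to compound 3 and its gap to compound 1 both lie beyond the scatter, so compound 2 is the weakest inhibitor of the set. Among the compounds with values here, compound 1 and compound 3 differ from compound 2 in several places at once, among them the substituent on the core and the substituents on the central ring, so no single-change step to compound 2 is available.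

Compound 4 `CC(C)(O)CNc1cc(Oc2ccc(NC(=O)Nc3cccc(C(F)(F)F)c3)cc2)ncn1` differs from compound 2 in one place: (2-hydroxy-2-methylpropyl)amino in place of methoxy on an aromatic carbon. Both compounds with strong inhibition, compound 1 and compound 3, carry an amino substituent at that place, whereas compound 2 carries methoxy. The expectation is therefore that the number falls; the size of the step from compound 2 to compound 4 is estimated as a 27-fold lower number from compound 2 to compound 4 (1.43 log units; beyond the scatter), a step beyond the scatter, with wide uncertainty since the other differences of compound 1 and compound 3 cannot be separated out. Compound 4 is expected to give 150 nM in this assay, within a range of 25 nM to 900 nM.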

Compound 4, half-maximal inhibitory concentration: 40 nM
Compound 4: middle estimate off by 3.8-fold (0.57 log units), on the high side, within the range that was stated.
By their numbers in this assay, from the lowest: compounds 1, 3 and 4 (each within the scatter of the next); then compound 2.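

In this assay, within the data shown here, the exchange of methoxy for (2-hydroxy-2-methylpropyl)amino gives a 100-fold lower number from compound 2 to compound 4 (2.00 log units; beyond the scatter) with the rest of the molecule unchanged, the first reading of this place through a single change, and it shows that this substituent alone can carry a large step. The central ring of compound 4 bears no fluorine or methyl substituents, so such substituents are not required for compound 4 to reach 40 nM in this assay, and this place on the aromatic carbon accepts a branched chain ending in a hydroxyl group. Nothing in the data gives a reason for the size of this step.

The exchange alters the atom attached to the aromatic carbon, the chain and the hydroxyl group all at once, and the compounds shown do not separate these three parts. Still open, from the compounds shown here alone, is how a plain amino group, methylamino on the unsubstituted central ring, isobutylamino (the same chain without its hydroxyl group) or a longer chain ending in a carboxylic acid would read at this place.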